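The compounds below may be only part of what the source reports. "The series", "measured", "known", "first", "only" and "open" are said of these compounds alone.

Measured compounds, cytotoxicity on PC-3 cells:

Compound 1 `CC(O)c1cccc(C(=O)N[C@@H](C)Cn2ccc(-c3ccc(C#N)c(Cl)c3)n2)c1`; in an ADME assay on PC-3 cells (Homo sapiens) for cytotoxicity, read by CCK-8 assay, with a stated time of 6 days (a higher number here means a weaker inhibitor, a lower number a stronger inhibitor), compound 1 gives > 30000 nM, which is a limit of the assay and not a number.
Compound 2 `COc1ccc(C(=O)N[C@@H](C)Cn2ccc(-c3ccc(C#N)c(Cl)c3)n2)cc1`; in this assay compound 2 gives > 30000 nM, again only a limit.
Compound 3 `C[C@@H](Cn1ccc(-c2ccc(C#N)c(Cl)c2)n1)NC(=O)c1ccccc1F`; in this assay compound 3 gives > 30000 nM, once more a limit.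

Compound 3 therefore has no numeric standing in this assay: it sits at the limit, and so do the two other values shown (the limit of > 30000 nM in this assay, at which 3 of the 3 values shown sit). The three steps among the measured compounds, each an exchange of the aryl group on the carbonyl carbon, are all left unreadable by these limits: a step that the two limits leave unreadable from compound 1 to compound 2, a step that the two limits leave unreadable from compound 1 to compound 3 and a step that the two limits leave unreadable from compound 2 to compound 3.

Compound 4 `C[C@@H](Cn1ccc(-c2ccc(C#N)c(Cl)c2)n1)NS(=O)(=O)c1cn(C)cn1` differs from compound 3 by (1-methyl-1H-imidazol-4-yl)sulfonyl in place of (2-fluorophenyl)carbonyl on an amine nitrogen. Within the data shown here, no measured step touches this change; the two steps that also alter the group on the amide side, from compound 1 to compound 3 and from compound 2 to compound 3, have no readable size, so no direction can be derived. The expectation is simply that compound 4 remains at or near the limit in this assay, with no step beyond the scatter: a step that the limit leaves unreadable from compound 3 to compound 4 is expected. The estimate for compound 4 is 40000 nM, with a range from 15000 nM to 120000 nM, and most likely only a limit will again be reported.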

Compound 4, half-maximal inhibitory concentration: > 30000 nM
Compound 4 ended at the assay's limit; the forecaster's own chance of this, stated with the estimate: 80%; the middle value does not contradict the limit.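

No new step can be read: compound 3 and compound 4 both stand at a limit in this assay, so exchanging (2-fluorophenyl)carbonyl for (1-methyl-1H-imidazol-4-yl)sulfonyl has no readable size. The compounds shown leave open how any of these groups on the amine nitrogen ranks in this assay, since none gives a number: the limit of > 30000 nM in this assay, at which 4 of the 4 values shown sit.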